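A few compounds are considered here, and "the series" means these few. Any claim that something is new, unique, unknown or untested is made for them only; others in the source may bear on it.

Measured so far:
compound 1 `C/C(C#Cc1ccccc1)=N\N/C(N)=N/S(=O)(=O)c1cc(C)c(Cl)cc1SCc1ccccc1Cl`: 129000 nM
compound 2 `Cc1cc(S(=O)(=O)/N=C(\N)N/N=C/C#Cc2ccccc2)c(SCc2cccc3ccccc23)cc1Cl`: 10000 nM

In a functional assay on HCT-116 cells (Homo sapiens) for antiproliferative activity, read by MTT assay, with a stated time of 72 h (on this read-out lower numbers stand for stronger inhibition and higher numbers for weaker inhibition), compound 2 gives the lowest of the two numbers; compound 1 sits a good deal higher, beyond the scatter. Compound 3 `C/C(C#Cc1ccccc1)=N\N/C(N)=N/S(=O)(=O)c1cc(C)c(Cl)cc1SCc1cccc2ccccc12` is not yet measured. It differs from compound 2 by a group of 11 heavy atoms (10 carbon, 1 nitrogen; one six-membered aromatic ring of carbon only) in place of a group of 10 heavy atoms (9 carbon, 1 nitrogen; one six-membered aromatic ring of carbon only), on an amine nitrogen. For the measured compounds named here, no step between measured compounds isolates this change; compound 1 carries the same entering group yet differs from compound 2 elsewhere too, so its weaker value cannot be assigned to this change alone. The expected step from compound 2 to compound 3 is a 3.0-fold higher number from compound 2 to compound 3 (0.48 log units; beyond the scatter), towards a higher number. Compound 3 is estimated at 30000 nM, range 6000 nM to 150000 nM.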

Compound 3, half-maximal inhibitory concentration: 105000 nM
Compound 3: the middle estimate sits 3.5-fold (0.54 log units) below what was measured, and the stated range covers the measured number.
By their numbers in this assay, from the lowest: compound 2; then compounds 3 and 1 (each within the scatter of the next).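

In this assay, with naphthalen-1-yl held constant, the group of 11 heavy atoms on the amine nitrogen gives an 11-fold higher number from compound 2 to compound 3 (1.02 log units; beyond the scatter) as a clean single-place reading, which compound 1 could not provide. With that group held constant, naphthalen-1-yl in place of 2-chlorophenyl gives a 1.2-fold lower number from compound 1 to compound 3 (0.09 log units; within the scatter) on the saturated chain carbon bound to a sulfur, so these two groups are not separated here. Nothing available explains either step.
Open, as far as these compounds go, is whether the group of 10 heavy atoms also gives the lower number with 2-chlorophenyl. Also open, from the compounds shown here alone, is how an amine or a carboxylic acid on the group at the amine nitrogen would read.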